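Swapping the aryl sulfonate ester: a single change

A few compounds are considered here, and "the series" means these few. Any claim that something is new, unique, unknown or untested is made for them only; others in the source may bear on it.

Measured so far:
Compound 1 `O=C(O)CCCCCCC(=O)Nc1ccc(C2=C(c3ccc(O)cc3)C3CC(S(=O)(=O)Oc4cccc5ccccc45)C2O3)cc1` — "not active" (no number reported)
Compound 2 `Cc1ccccc1OS(=O)(=O)C1CC2OC1C(c1ccc(NC(=O)CCCCCCC(=O)O)cc1)=C2c1ccc(O)cc1` — 5010 nM

In an assay on isolated protein for inhibition of protein deacetylase HDAC6 (Homo sapiens), read by fluorescence, with a stated time of 15 min (a lower number here means a stronger inhibitor, a higher number a weaker inhibitor), compound 2 gives 5010 nM, the only numerical result among the two compounds. Within the data shown here, compound 1 is reported only as "not active" (no number reported), without a number, so no step between the two can be sized.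

Compound 3 `O=C(O)CCCCCCC(=O)Nc1ccc(C2=C(c3ccc(O)cc3)C3CC(S(=O)(=O)Oc4ccc(C(F)(F)F)cc4)C2O3)cc1` has not yet been measured. It differs from compound 2 in one place: 4-(trifluoromethyl)phenyl in place of 2-methylphenyl on an oxygen. Both groups sit on the oxygen attached to the sulfonyl sulfur, and neither carries hydrogen-bond donors or acceptors, so the shared core and the rest of the molecule stay the same.

Among the measured compounds shown here, with no measured step of this kind to lean on, the expectation is that compound 3 stays close to compound 2, with a step in this assay from compound 2 to compound 3 of about a 1.1-fold lower number from compound 2 to compound 3 (0.05 log units; within the scatter), which is within the usual scatter. Compound 3 is therefore estimated at 4500 nM, with a likely range of 1500 nM to 14000 nM.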

Compound 3, half-maximal inhibitory concentration: 648 nM
For compound 3 the middle estimate is 6.9-fold (0.84 log units) above the measured one, outside the stated range (below it).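

In this assay, the group on the oxygen attached to the sulfonyl sulfur clearly matters: 4-(trifluoromethyl)phenyl in place of 2-methylphenyl gives a 7.7-fold lower number from compound 2 to compound 3 (0.89 log units; beyond the scatter). The two groups have the same hydrogen-bond donor and acceptor counts and the same kind of aromatic ring, so those counts alone do not predict this result, and steps involving compound 1 cannot be read without a number. No measurement available here bears on the reason for this step.

This single swap changes both the substituent and its numbered location on the ring, so the two contributions cannot be separated. As far as these compounds go, whether 4-methylphenyl or 2-(trifluoromethyl)phenyl would behave more like compound 2 or compound 3 remains open, as does the effect of an amine on that ring.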